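Ring-nitrogen substituent swaps: flat displacement numbers so far

A few compounds are considered here, and "the series" means these few. Any claim that something is new, unique, unknown or untested is made for them only; others in the source may bear on it.

Measured compounds:
compound 1 `CC(C)N1CCN(Cc2csc(N)c2C(=O)c2ccc(Cl)cc2)CC1` — 0%
compound 2 `Nc1scc(CN2CCN(c3ccc(Cl)cc3F)CC2)c1C(=O)c1ccc(Cl)cc1` — 0%
compound 3 `Nc1scc(CN2CCN(c3cccc(F)c3)CC2)c1C(=O)c1ccc(Cl)cc1` — 1%

All three share one core and differ only in the group on the amine nitrogen in the six-membered non-aromatic ring with two nitrogens. In an assay on CHO cells for displacement of a labelled ligand from adenosine receptor A1 (Homo sapiens), read by scintillation counting, with a stated time of 120 min, tested at 10 uM (on this read-out lower numbers stand for less inhibition and higher numbers for more inhibition at the one concentration tested (going by the name of the read-out)), none of them shows displacement worth the name. Compound 2 stands level with compound 1 at the digits recorded, the two together the lowest of the three numbers; its nearest neighbour is compound 1 with no change at the digits printed from compound 1 to compound 2 (within the scatter), its furthest compound 3 with a number 1 percentage points higher from compound 2 to compound 3 (within the scatter). The third step, a number 1 percentage points higher from compound 1 to compound 3 (within the scatter), is also within the scatter, so the three measurements are indistinguishable.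

Compound 4 `Nc1scc(CN2CCN(c3cccc(F)c3F)CC2)c1C(=O)c1ccc(Cl)cc1` is not yet measured. Relative to compound 2 the change is 2,3-difluorophenyl in place of 4-chloro-2-fluorophenyl on an amine nitrogen in a ring.

All three measured steps bear on this change, since each exchanges the group on the same ring nitrogen, and none of them moved the read-out beyond the scatter. On that basis the step from compound 2 to compound 4 is expected to be a number 2 percentage points higher from compound 2 to compound 4 (within the scatter), with no direction beyond the scatter. For compound 4 in this assay the estimate is 2%, with a range of 0% to 12%.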

Compound 4, a percentage reported as inhibition, at one concentration (the size of the read-out at that concentration, not a potency): 0%
Beside the measured number, compound 4's estimate is 2 percentage points above it, within the range that was stated.
By their numbers in this assay, from the lowest: compounds 1, 2, 4 and 3 (each within the scatter of the next).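

In this assay, the 2,3-difluorophenyl group adds a second exchange of one aryl group for another on the amine nitrogen in a ring, with no change at the digits printed from compound 2 to compound 4 (within the scatter), and the exchange of an aryl group for isopropyl again leaves the read-out flat, with no change at the digits printed from compound 1 to compound 4 (within the scatter). The series now also holds its smallest change at this position, fluoro in place of hydrogen on an aromatic carbon of the 3-fluorophenyl group, and that single-atom edit gives a number 1 percentage points lower from compound 3 to compound 4 (within the scatter), so the flat read-out now spans both whole-group exchanges and a single-atom edit. Nothing measured accounts for this flatness, and no independent data bear on it.

The compounds shown leave open whether a phenyl ring carrying a carboxylic acid or an aminomethyl group, or a longer chain such as n-hexyl in place of the aryl group on this nitrogen, would lift the number above the scatter. On these data alone, every compound here also carries the same core, so whether the flat read-out holds with a different group in place of the 4-chlorobenzoyl group remains untested by these data.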